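The compounds below may be only part of what the source reports. "The series", "measured", "known", "first", "only" and "open" are said of these compounds alone.

Working notes on the series. Three compounds have numbers in a physicochemical assay for lipophilicity, using the shake flask method, in phosphate buffer, measured as octanol-water partition, with a stated time of 30 min, at pH 7.4; a lower number here means a more polar compound, a higher number a more lipophilic compound. Compound 2, `Cc1nccn1-c1cnc(NCc2c(F)ccc3c2CCO3)c2cn[nH]c(=O)c12`, gives 2.1. Compound 1, `Cc1ncccc1-c1cnc(NCc2c(F)ccc3c2CCO3)c2nn(CC#N)c(=O)n12`, gives 2.2 in this assay, and this value and that of compound 2 lie within the scatter of each other, so no order between the two is claimed. Compound 3, `CN(C)Cc1ccc2c(c1)CN(c1cnc(NCc3c(F)ccc4c3CCO4)n3cnnc13)C2=O`, gives 1.6 in this assay, and this value is lower than that of compound 2 by more than the scatter; compound 3 is thus the most polar of the three, while compound 2 sits with compound 1 at the upper end of the range seen so far.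

Going by the values given here, no pair of measured compounds differs in a single place, so no measured step is available for direct comparison.

Compound 4, `Cc1ncccc1-c1cnc(NCc2c(F)ccc3c2CCO3)c2cn[nH]c(=O)c12`, is not yet measured in this assay. It differs from compound 2 in one place: 2-methylpyridin-3-yl in place of 2-methyl-1H-imidazol-1-yl on an aromatic carbon.

Among the compounds with values here, compound 1, which carries the 2-methylpyridin-3-yl group on a different core, gives 2.2 in this assay; its value is within the scatter of compound 2, so the present data give no measured step for this kind of exchange. A moderate upward step is nevertheless expected, a number 0.60 log units higher from compound 2 to compound 4 (beyond the scatter). Compound 4 is estimated at 2.7 in this assay, within a range from 2.2 to 3.2.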

Compound 4, distribution coefficient: 3
Compound 4: the middle estimate sits 0.30 log units below what was measured; measured number inside the range.
By their numbers in this assay, from the lowest: compound 3; then compounds 2 and 1 (each within the scatter of the next); then compound 4.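

In this assay, going by these compounds alone, the position on the aromatic carbon, para to a large group, now has a measured step: 2-methylpyridin-3-yl in place of 2-methyl-1H-imidazol-1-yl gives a number 0.90 log units higher from compound 2 to compound 4 (beyond the scatter) on an otherwise unchanged structure, the first single-place step. The exchange swaps a five-membered aromatic ring with 2 hetero atoms for a six-membered aromatic ring with 1 hetero atom, and it also changes the heavy-atom count from 6 to 7 and the hydrogen-bond acceptor count from 2 to 1, so this one step cannot assign the shift to any one of these differences. Nothing measured independently here bears on why the number moves by this amount.

On these data alone, whether the same exchange gives a step of similar size on the core of compound 1 remains open, as this step has been read on one core only. Also open, as far as these compounds go, is where a compound with an amine or a carboxylic acid at this position would fall in this assay and whether such groups would extend the range of the series.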